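The source may hold more compounds than are shown below. What is called first, only, known or untested is meant among the compounds shown, and "the series" means these compounds.

Measured in a functional assay on DU-145 cells (Homo sapiens) for cytotoxicity, read by MTT assay, with a stated time of 72 h; on this read-out higher numbers stand for weaker inhibition of growth and lower numbers for stronger inhibition of growth:
- Compound 1 `N#C/C(=C/c1ccc2ccccc2c1)C(=O)c1ccc[nH]1`: < 10000 nM (a limit)
- Compound 2 `N#C/C(=C/c1ccc(Cl)cc1)C(=O)c1ccc[nH]1`: 32000 nM
- Compound 3 `N#C/C(=C/c1ccc(Cl)c(Cl)c1)C(=O)c1ccc[nH]1`: < 10000 nM (a limit)

Among the compounds with values here, compound 2, at 32000 nM, holds the only true number in this small set. The other values are the limit of < 10000 nM in this assay, at which 2 of the 3 values shown sit.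

Compound 4 `COc1ccc(/C=C(/C#N)C(=O)c2ccc[nH]2)cc1` has not yet been measured. It carries methoxy in place of chloro on an aromatic carbon, para to a large group: methoxy in place of chloro on an aromatic carbon.

Within the data shown here, only one measured step bears on this, and loosely: an at least 3.2-fold lower number from compound 2 to compound 3 (0.50 log units; beyond the scatter). That step adds a chloro rather than replacing one, and it rests on a limit. Little movement is therefore expected in this assay, with no step beyond the scatter and a slight lean towards a lower number. The estimated step is a 1.6-fold lower number from compound 2 to compound 4 (0.20 log units; within the scatter). For compound 4 the expected value is 20000 nM, with an estimated range of 6000 nM to 60000 nM.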

Compound 4, concentration for 50% growth inhibition: < 10000 nM
Compound 4 ended at the assay's limit; the forecaster's own chance of this, stated with the estimate: 30%; middle value at least 2.0-fold (0.30 log units) away from the limit.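

In this assay, methoxy in place of chloro, para to a large group, gives an at least 3.2-fold lower number from compound 2 to compound 4 (0.50 log units; beyond the scatter). The chloro is therefore not required at this position for a lower number, and exchanging it, not only adding a further chloro as in compound 3, moves the value beyond the scatter. The value of compound 4 is a limit, so the true size of this step stays unknown, and compound 4 joins most of the set: the limit of < 10000 nM in this assay, at which 3 of the 4 values shown sit.

Compounds 1, 3 and 4 cannot be ordered, and the steps among them cannot be read. On these data alone, whether an amine or a carboxylic acid at this position would also give a lower number stays open.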